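The compounds below may be only part of what the source reports. "The series", "measured", "known", "first", "only" and "open" are said of these compounds alone.

Measured compounds:
compound 1 `CCOC(=O)c1c(C)nc(-c2cccc(C#N)c2)n1C(C)C`: 9260 nM
compound 2 `C=CCOn1c(-c2cccc(C#N)c2)nc(C)c1C(=O)OCC`: 5860 nM
compound 3 `CCOC(=O)c1c(C)nc(-c2cccc(C#N)c2)n1OCc1ccccc1`: 5930 nM

Of the compounds shown here, three sharing one core have been measured in a functional assay on a cell-free system (plasma, Oryctolagus cuniculus) for inhibition, with stated times of 5 min, 1 min and 6 min; a lower number here means a stronger inhibitor, a higher number a weaker inhibitor. Compound 1 `CCOC(=O)c1c(C)nc(-c2cccc(C#N)c2)n1C(C)C` gives 9260 nM. Compound 2 `C=CCOn1c(-c2cccc(C#N)c2)nc(C)c1C(=O)OCC` gives 5860 nM, and compound 3 `CCOC(=O)c1c(C)nc(-c2cccc(C#N)c2)n1OCc1ccccc1` gives 5930 nM. Among these numbers compound 3 has the second highest, yet every step between the three is small: a 1.6-fold lower number from compound 1 to compound 2 (0.20 log units; within the scatter), a 1.6-fold lower number from compound 1 to compound 3 (0.19 log units; within the scatter), and a 1.0-fold higher number from compound 2 to compound 3 (0.01 log units; within the scatter). All three thus sit within the scatter of one another, and the substituent on the aromatic nitrogen, whether isopropyl, allyloxy or benzyloxy, has so far not moved the read-out in a way that can be told apart from repeat measurements.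

Compound 4 `CCOC(=O)c1c(C)nc(-c2cccc(C#N)c2)n1OCc1ccc(OC)cc1` continues from compound 3 by a change further out on the benzyloxy group: methoxy in place of hydrogen on an aromatic carbon. Within the data shown here, no measured step touches this position. Among the measured compounds shown here, the only steps that bear on the region at all are the three above, each within the scatter, and the nearest of them, benzyl in place of vinyl, reads a 1.0-fold higher number from compound 2 to compound 3 (0.01 log units; within the scatter). An expectation built on these steps is therefore one of no change beyond the scatter; the expected step is a 1.1-fold lower number from compound 3 to compound 4 (0.03 log units; within the scatter). Compound 4 is estimated at 5500 nM, with a range from 2500 nM to 12000 nM.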

Compound 4, half-maximal inhibitory concentration: 6830 nM
Beside the measured number, compound 4's estimate is 1.2-fold (0.09 log units) below it; the measured number falls inside the stated range.
By their numbers in this assay, from the lowest: compounds 2, 3, 4 and 1 (each within the scatter of the next).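

In this assay, among these compounds, methoxy in place of hydrogen on an aromatic carbon, para to a large group, gives a 1.2-fold higher number from compound 3 to compound 4 (0.06 log units; within the scatter), the first reading from a change on the aromatic ring of the benzyloxy group, and the added methoxy does not separate compound 4 from compound 3. The wider replacement of 4-methoxyphenyl in place of vinyl on a saturated chain carbon bound to an oxygen on an aromatic ring gives a 1.2-fold higher number from compound 2 to compound 4 (0.07 log units; within the scatter), so the substituent on the aromatic nitrogen can reach this far out with no difference that can be told from repeat measurements. No measurement at hand offers an explanation for this flat reading.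

As far as these compounds go, whether a different group on this aromatic carbon, such as an amine, a carboxylic acid or trifluoromethyl, would carry the number beyond the scatter remains open, as does the effect of methoxy on another carbon of the same ring. Also open is whether a longer chain on the aromatic nitrogen, or a change to the nitrile or the ethyl ester of the shared core, would give a step larger than any seen among these four compounds.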